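The compounds below may be only part of what the source reports. "The series", "measured", "known", "first", "only" and "open" are said of these compounds alone.

Measured compounds:
Compound 1, `CC1CCN(c2ccc(Nc3ncc4c(n3)N(C3CCCC3)CC(=O)N4C)nc2)CC1`: in a functional assay on HeLa cells (Homo sapiens) for inhibition, read by MTT assay, with a stated time of 48 h (a higher number here means a weaker inhibitor, a lower number a stronger inhibitor), compound 1 gives > 30000 nM, which is a limit of the assay and not a number.
Compound 2, `CCN1C(=O)CN(C2CCCC2)c2nc(Nc3ccc(N4CCCCC4)cn3)ncc21`: in this assay compound 2 gives 17600 nM.

Going by the values given here, compound 2 stands as the only numbered value in this assay; the one other result, that of compound 1, is a limit, (the limit of > 30000 nM in this assay, at which 1 of the 2 values shown sits), so compound 2 is simply the member of the pair that returned a number. Among the compounds with values here, no step between measured compounds differing in a single place exists in this set, so there is no measured precedent to lean on.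

Compound 3, `CCN1C(=O)CN(C2CCCC2)c2nc(Nc3ccc(N4CCC(C)CC4)cn3)ncc21`, is not yet measured. It differs from compound 2 by methyl in place of hydrogen on a saturated ring carbon, piperidin-1-yl to 4-methylpiperidin-1-yl. Compound 1 carries the same 4-methylpiperidin-1-yl group but differs from compound 2 at a second place as well, so it gives no clean reading of this change on its own. Against a background of one weak number and one limit, the expected step from compound 2 to compound 3 is a 1.4-fold higher number from compound 2 to compound 3 (0.15 log units; within the scatter), a modest weakening that may not exceed the scatter. Compound 3 is estimated at 25000 nM in this assay, with a range from 9000 nM to 70000 nM and a real chance that only a limit is reported.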

Compound 3, half-maximal inhibitory concentration: > 30000 nM
Compound 3 ended at the assay's limit (the forecaster's own chance of this, stated with the estimate: 40%); middle value at least 1.2-fold (0.07 log units) away from the limit.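

The step from piperidin-1-yl to 4-methylpiperidin-1-yl now has its first clean reading, with methyl in place of hydrogen on a saturated ring carbon, three ring bonds from the ring nitrogen: in this assay it is an at least 1.7-fold higher number from compound 2 to compound 3 (0.23 log units; that floor lies within the scatter). The result for compound 3 is a limit of the assay and not a number, so the step has only a floor, and the change is not shown to exceed the scatter; its true size stays open on the upper side. The step from compound 1 to compound 3 cannot be read, because both results are limits: the limit of > 30000 nM in this assay, at which 2 of the 3 values shown sit.

Still open, as far as these compounds go, is whether an amine, a hydroxyl or a carboxylic acid on that same ring carbon would give a readable number in this assay, where compound 2 gives 17600 nM. Also open, from the compounds shown here alone, is what a longer chain, such as propyl, would do on the amide-type nitrogen of the shared core, given that the present pair offers no readable comparison at that place.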